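Compound 1 to compound 4: 4-hydroxyphenyl to 4-methylphenyl

This account rests on a few compounds, and the source may have more. Where it says the series, first, only, none or still open, it means among the compounds named here.

In a functional assay on HepG2 cells (Homo sapiens) for inhibition, read by MTT assay, with a stated time of 48 h (a higher number here means a weaker inhibitor, a lower number a stronger inhibitor), compound 1 `COc1cc(C(=O)/C=C/c2ccc(O)cc2)cc(OC)c1OC` gives 16000 nM and compound 3 `COc1cc(C(=O)/C=C/c2ccc(O)c(O)c2)cc(OC)c1OC` gives 14900 nM, so these two numbers lie within the scatter of each other. Compound 1 therefore shares its standing with compound 3 among the numerical results. Compound 2 `COc1ccc(/C=C/C(=O)c2cc(OC)c(OC)c(OC)c2)c(OC)c1` lacks a hydroxy and stands at > 100000 nM, a limit of the assay and not a number.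

Compound 4 `COc1cc(C(=O)/C=C/c2ccc(C)cc2)cc(OC)c1OC` differs from compound 1 by methyl in place of hydroxy on an aromatic carbon, para to a large group: methyl in place of hydroxy on an aromatic carbon.

Among the measured compounds shown here, the only measured step, a 1.1-fold lower number from compound 1 to compound 3 (0.03 log units; within the scatter), adds a hydroxy in place of hydrogen and stays within the scatter. For the measured compounds named here, it bears only loosely on the change, and no measured step removes the hydroxy of compound 1. A modest move towards a higher number in this assay is expected, with wide uncertainty. The expected step is a 1.6-fold higher number from compound 1 to compound 4 (0.19 log units; within the scatter). Compound 4 is estimated at 25000 nM, with an expected range of 8000 nM to 90000 nM.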

Compound 4, half-maximal inhibitory concentration: 52000 nM
The estimate for compound 4 lay 2.1-fold (0.32 log units) below the measured number; low and high end bracket the measured number.
By their numbers in this assay, from the lowest: compounds 3 and 1 (each within the scatter of the next); then compound 4. At a limit, above all of these: compound 2.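

In this assay, methyl in place of hydroxy on the aromatic carbon gives a 3.3-fold higher number from compound 1 to compound 4 (0.51 log units; beyond the scatter); unlike the earlier addition of a hydroxy to this ring, this change lies beyond the scatter, so the group at this position does register in the read-out. The comparison with the 3,4-dihydroxyphenyl analogue reads the same way, with a 3.5-fold higher number from compound 3 to compound 4 (0.54 log units; beyond the scatter), and both compounds that keep a hydroxy on this ring give lower numbers than the methyl compound. No measurement at hand accounts for this step.

An amine or a carboxylic acid at this place, or plain hydrogen, remains to be read against the hydroxy and methyl groups. Going by these compounds, whether the step holds in any other cell line also stays open.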